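The source may hold more compounds than are shown below. What is called first, only, known or untested is meant among the compounds shown, and "the series" means these compounds.

Measured so far:
compound 1 `CCNC(=O)c1noc(-c2cc(C(C)C)c(O)cc2O)c1-c1cc(CO)no1`: 5 nM in a functional assay on A2780 cells (Homo sapiens) for inhibition; a higher number here means a weaker inhibitor, a lower number a stronger inhibitor
compound 2 `CCNC(=O)c1noc(-c2cc(C(C)C)c(O)cc2O)c1-c1cc(COCC(=O)OC)no1`: "not determined" (no result reported) in this assay

For the measured compounds named here, compound 1 holds the only number in this assay; compound 2 gives nothing to compare against, so compound 1 stands alone. Compound 3 `CCNC(=O)c1noc(-c2cc(C(C)C)c(O)cc2O)c1-c1cc(CN(CC)CC)no1` differs from compound 1 by a single change, (diethylamino in place of hydroxy on a saturated chain carbon bound to an aromatic carbon). Going by the values given here, no measured pair shows this kind of change, so the expected step from compound 1 to compound 3 in this assay rests on the structural change alone: a small move, more likely toward a weaker inhibitor than a stronger one, and possibly within the scatter. The expected step is a 2.0-fold higher number from compound 1 to compound 3 (0.30 log units; within the scatter). Compound 3 is estimated at 10 nM, with a range from 3 nM to 40 nM.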

Compound 3, half-maximal inhibitory concentration: 78 nM
For compound 3 the middle estimate is 7.8-fold (0.89 log units) below the measured one, and the stated range ends below it.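

In this assay, the position on the saturated chain carbon bound to an aromatic carbon does not tolerate every group equally: diethylamino in place of hydroxy gives a 16-fold higher number from compound 1 to compound 3 (1.19 log units; beyond the scatter). For the compounds shown here, this is the first readable change at this position, and it lies beyond the scatter, so the group placed here matters. No measurement shown gives a reason for the step. The compounds shown leave open whether the nitrogen or the two ethyl groups drive the step. A primary amine, dimethylamino or a methoxy group at this position would separate the two.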